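A fluoro step from compound 1 to compound 3

A few compounds are considered here, and "the series" means these few. Any claim that something is new, unique, unknown or untested is made for them only; others in the source may bear on it.

Of the compounds shown here, two sharing one core have been measured so far in a functional assay on A-375 cells (Homo sapiens) for inhibition, read by MTT assay, with a stated time of 4 days (a higher number here means a weaker inhibitor, a lower number a stronger inhibitor), and they differ clearly. Compound 1 (`CN1C[C@@H]2C[C@H]1CN2c1ccc(-c2ccnc3c(-c4cccc5[nH]ncc45)c(-c4ccncc4)nn23)cc1`) gives 202 nM and holds the lower number of the pair, which makes it the stronger inhibitor of the two. Compound 2 (`CN(C)c1cc(N2C[C@@H]3C[C@H]2CN3C)ccc1-c1ccnc2c(-c3cccc4[nH]ncc34)c(-c3ccncc3)nn12`) gives 1850 nM and carries dimethylamino in place of hydrogen on an aromatic carbon. Among the compounds with values here, the only measured step is a 9.2-fold higher number from compound 1 to compound 2 (0.96 log units; beyond the scatter) and it leaves the 1H-indazol-4-yl group untouched.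

Compound 3 (`CN1C[C@@H]2C[C@H]1CN2c1ccc(-c2ccnc3c(-c4ccc(F)c5[nH]ncc45)c(-c4ccncc4)nn23)cc1`) changes exactly that group. The difference is fluoro in place of hydrogen on an aromatic carbon and it turns 1H-indazol-4-yl into 7-fluoro-1H-indazol-4-yl, with fluoro in place of hydrogen on an aromatic carbon. Within the data shown here, no measured step covers this group, so the dimethylamino step offers no direct guide to the size of this one. For compound 3 only a small change is expected, an estimated 1.1-fold higher number from compound 1 to compound 3 (0.04 log units; within the scatter) that would stay within the scatter. In this assay compound 3 is estimated at 220 nM and is expected to fall from 90 nM to 520 nM in four of five measurements.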

Compound 3, half-maximal inhibitory concentration: 68 nM
Beside the measured number, compound 3's estimate is 3.2-fold (0.51 log units) above it; measured number outside the range, below it.
By their numbers in this assay, from the lowest: compound 3; then compound 1; then compound 2.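

Replacing hydrogen with fluoro on the 1H-indazol-4-yl group gives a 3.0-fold lower number from compound 1 to compound 3 (0.47 log units; beyond the scatter) in this assay, which shows that this group, untouched by the earlier step, is a place where a single added heavy atom can move the number beyond the scatter, here toward a stronger inhibitor. Within the data shown here, the earlier dimethylamino change, a 9.2-fold higher number from compound 1 to compound 2 (0.96 log units; beyond the scatter), went the other way in a different place, so the fluoro change is the first single change from compound 1 seen to lower the number. Nothing given here accounts for the direction or the size of this step.

The compounds shown leave open whether this gain belongs to fluoro itself or would also follow from another group in the same place, such as chloro, methyl or methoxy, and whether fluoro elsewhere on the six-membered ring of the indazole would act alike. They also leave open whether the same change would lower the number on the dimethylamino-bearing compound 2 by a similar amount.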